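The source may report more compounds than this note shows. Statements on the series, on what has been measured and on what is new or still open speak of the compounds shown alone.

Compound 1, `N=c1oc2ccc(Br)cc2cc1C(=O)NCC(O)CO`, gives 11% in an assay on CHO cells for displacement of a labelled ligand from adenosine receptor A1 (Homo sapiens), read by scintillation counting, with a stated time of 60 min, tested at 10 uM; a higher number here means more inhibition at the concentration tested (going by the name of the read-out), a lower number less inhibition.
Compound 2, `COc1cccc2cc(C(=O)NCCO)c(=N)oc12`, gives 47% in this assay.
Compound 3, `COc1cccc2cc(C(=O)N[C@@H](CO)C(=O)O)c(=O)oc12`, gives 12% in this assay.

Among these three measured compounds, compound 2 stands highest in this assay, with compound 3 closest to it and compound 1 furthest, both gaps lying beyond the usual scatter. Compound 4, `COc1cccc2cc(C(=O)NC(CO)(CO)CO)c(=N)oc12`, has not yet been measured. It differs from compound 2 at one place: 2-hydroxy-1,1-bis(hydroxymethyl)ethyl in place of 2-hydroxyethyl on an amide-type nitrogen. For the measured compounds named here, no step between two measured compounds bears on this change, so the size of the move cannot be read from a measured pair. What the three compounds show is that compound 2 carries the smaller group on the amide nitrogen and the highest number, while compound 3, with a larger amide substituent on a related core, sits far lower. On that basis a downward step is expected for the move to compound 4, roughly a number 17 percentage points lower from compound 2 to compound 4 (beyond the scatter), with wide uncertainty. Compound 4 is estimated to give 30% in this assay, within a range from 10% to 52%.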

Compound 4, a percentage reported as inhibition, at one concentration (the size of the read-out at that concentration, not a potency): 19%
Compound 4: middle estimate off by 11 percentage points, on the high side; low and high end bracket the measured number.
By their numbers in this assay, from the lowest: compounds 1, 3 and 4 (each within the scatter of the next); then compound 2.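

Placing 2-hydroxy-1,1-bis(hydroxymethyl)ethyl in place of 2-hydroxyethyl on this amide-type nitrogen gives a number 28 percentage points lower from compound 2 to compound 4 (beyond the scatter) in this assay, the first direct measure of a change at this position on the shared core. The step shows that the number at this position depends on the amide substituent, and that this exchange, from 3 heavy atoms to 7, does not preserve the inhibition. A single pair cannot separate the added carbon atoms, the added hydroxyl groups and the branching, and no measurement shown gives a reason for the drop.

Going by these compounds, it remains open whether a simple ethyl group or a longer chain such as 3-hydroxypropyl would keep the number seen for compound 2 at 47%. Also open, on these data alone, is whether an amine or a carboxylic acid on the chain would lower it, and whether this exchange would give a similar step on the core of compound 1.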